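Benzyl in place of ethyl on a dithiocarbamate sulfur

The compounds below may be only part of what the source reports. "The series", "measured", "known", "first", "only" and "open" are said of these compounds alone.

Among the measured compounds shown here, compound 2, `CCSC(=S)N1CCN(C(=S)SC(=S)N(C)C)CC1`, sits at the high end of the two values so far in an ADME assay on HeLa cells (Homo sapiens) for cytotoxicity, read by MTT assay, with a stated time of 24 h; a higher number here means a weaker inhibitor, a lower number a stronger inhibitor: compound 2 gives 4480000 nM, while compound 1, `CN(C)C(=S)SC(=S)N1CCN(c2ccccc2)CC1`, gives 1610000 nM. For the measured compounds named here, the one measured step, a 2.8-fold higher number from compound 1 to compound 2 (0.44 log units; beyond the scatter), replaced a phenyl group on the ring nitrogen with the ethylsulfanyl thiocarbonyl group and raised the number modestly.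

Compound 3, `CN(C)C(=S)SC(=S)N1CCN(C(=S)SCc2ccccc2)CC1`, keeps the whole of compound 2 and changes only the tail on the sulfur: phenyl in place of methyl on a saturated chain carbon bound to a sulfur. Going by the values given here, no measured pair shows this exact exchange. Among the compounds with values here, the step from compound 1 to compound 2 is the only guide, and it concerns a different position, so it bears only loosely on the new change; it shows that an aromatic ring elsewhere went with a somewhat lower number. On that thin basis a small move toward a lower number, or none beyond the scatter, is expected, so the estimated step is a 1.7-fold lower number from compound 2 to compound 3 (0.24 log units; within the scatter). Compound 3 is expected to give about 2600000 nM in this assay, with a range from 900000 nM to 7500000 nM.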

Compound 3, half-maximal inhibitory concentration: > 5000000 nM
Compound 3: no number, only a limit (the forecaster's own chance of this, stated with the estimate: 10%); middle value at least 1.9-fold (0.28 log units) away from the limit.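

In this assay, compound 3 gives > 5000000 nM, which is a limit of the assay and not a number. Exchanging ethyl for benzyl on the sulfur brings an at least 1.1-fold higher number from compound 2 to compound 3 (0.04 log units; that floor lies within the scatter), so the added phenyl ring does not go with a lower number at this position, unlike the earlier step, where the compound with a phenyl group on the ring nitrogen held the lower number of the pair. Only a floor is known for this new step, and since that floor lies within the scatter, the data cannot say how large the change really is, or even whether it exceeds the usual spread of repeated measurements: the limit of > 5000000 nM in this assay, at which 1 of the 3 values shown sits.

From the compounds shown here alone, what remains open is how other groups on this sulfur would behave, such as a propyl chain or a longer chain, or a chain ending in an amine or a carboxylic acid, and whether any of them would give a number that can be read inside the range of the assay. With one step at each of the two positions, no general rule about aromatic rings in this series can be drawn.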